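From a vinyl group to a hydroxy group on the sulfonyl ring

The compounds below may be only part of what the source reports. "The series", "measured", "known", "first", "only" and "open" are said of these compounds alone.

Compound 1 `O=S(=O)(Nc1ccc(-c2nc3ccccc3o2)cc1)c1cccc(F)c1` and compound 2 `C=Cc1ccc(S(=O)(=O)Nc2ccc(-c3nc4ccccc4o3)cc2)cc1` share one core and differ only in the ring on the sulfonyl sulfur. In an assay on cells for inhibition of HSP60/HSP10 (Homo sapiens), with a stated time of 60 min (on this read-out lower numbers stand for stronger inhibition and higher numbers for weaker inhibition), compound 1 gives 71000 nM. For compound 2 this assay reports only a limit, > 100000 nM. The step of an at least 1.4-fold higher number from compound 1 to compound 2 (0.14 log units; that floor lies within the scatter), 4-vinylphenyl in place of 3-fluorophenyl on a sulfonyl sulfur, sits at the limit of > 100000 nM in this assay, at which 1 of the 2 values shown sits, so compound 2 stands at that limit among the two values shown and has no number of its own.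

Compound 3 `O=S(=O)(Nc1ccc(-c2nc3ccccc3o2)cc1)c1ccc(O)cc1` is the compound not yet measured. Its difference from compound 2 is hydroxy in place of vinyl on an aromatic carbon. Within the data shown here, only one measured step touches this part of the molecule, an at least 1.4-fold higher number from compound 1 to compound 2 (0.14 log units; that floor lies within the scatter), and it is a floor within the scatter; no measured step exchanges a vinyl group for a hydroxy group, so the data give no direction for the change. The expected step is therefore small, an at least 1.1-fold lower number from compound 2 to compound 3 (0.04 log units; that floor lies within the scatter), without a direction beyond the scatter. Compound 3 is thus estimated at 90000 nM in this assay, within a range from 35000 nM to 250000 nM.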

Compound 3, half-maximal inhibitory concentration: 78000 nM
Estimate against measurement, compound 3: 1.2-fold (0.06 log units) above; measured number inside the range.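

The 4-hydroxyphenyl ring of compound 3 gives a measured number in this assay for a group para to a large group, which the 4-vinylphenyl ring of compound 2 did not. The exchange of vinyl for hydroxy reads as an at least 1.2-fold lower number from compound 2 to compound 3 (0.10 log units; that floor lies within the scatter), a floor and not a full size, and compound 2 stays a limit and not a number: the limit of > 100000 nM in this assay, at which 1 of the 3 values shown sits. Set against the 3-fluorophenyl ring, the 4-hydroxyphenyl ring gives a 1.1-fold higher number from compound 1 to compound 3 (0.04 log units; within the scatter), so these two rings cannot be told apart on this read-out, and a hydrogen-bond donor and acceptor entering at this place comes with no measurable gain over the fluorine compound.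

As far as these compounds go, whether an amine or a carboxylic acid at this place on the ring would move the number beyond the scatter from those of compound 1 and compound 3 stays open. Compound 1 and compound 3 differ both in the group and in where it sits on the ring, so the part played by each of the two remains unseparated.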